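The source may report more compounds than this note shows. Statements on the series, on what has been measured and on what is new or still open speak of the compounds shown alone.

Working notes on the series. Compound 1 `Cc1nc2c(CCc3ccccc3)cccn2c1N` and compound 3 `CCNc1c(C)nc2c(CCc3ccccc3)cccn12` share one core; compound 2 `Cc1nc2c(OCc3ccccc3)nccn2c1N` and the as yet unmeasured compound 4 `CCNc1c(C)nc2c(OCc3ccccc3)nccn12` share another. How the core of compound 2 differs from the core of compound 1 is not broken down here.

In a functional assay on the whole organism with Rattus norvegicus as the target (on this read-out higher numbers stand for an effect only at larger amounts of compound and lower numbers for an effect already at smaller amounts), compound 1 gives 9 mg/kg. In this assay compound 3 gives 5.2 mg/kg. The change from compound 1 to compound 3 is ethyl in place of hydrogen on a nitrogen on an aromatic ring, and it produced a 1.7-fold lower number from compound 1 to compound 3 (0.24 log units; within the scatter). In this assay compound 2 gives 5 mg/kg; set against compound 3 and against compound 1 this lies within the scatter in both cases, so no order among the three measured compounds is claimed.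

Compound 4 carries the same change on the core of compound 2: ethyl in place of hydrogen on a nitrogen on an aromatic ring. Among the compounds here this change occurs twice, once measured and once not, and the two place descriptions agree word for word, so it is taken as the same change. With a single measured instance there is nothing to check it against on the second core. The expectation for compound 4 therefore rests on compound 3, whose step a 1.7-fold lower number from compound 1 to compound 3 (0.24 log units; within the scatter) was small, applied to compound 2 at 5 mg/kg.

The step from compound 2 to compound 4 is expected to be a 1.4-fold lower number from compound 2 to compound 4 (0.15 log units; within the scatter), of about the same small size. Compound 4 is estimated at 3.5 mg/kg, with the range from 1.5 mg/kg to 8 mg/kg.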

Compound 4, dose for half-maximal effect: 6 mg/kg
Beside the measured number, compound 4's estimate is 1.7-fold (0.23 log units) below it, within the range that was stated.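

In this assay ethyl in place of hydrogen on a nitrogen on an aromatic ring gives a 1.2-fold higher number from compound 2 to compound 4 (0.08 log units; within the scatter), so on the core of compound 2, as on the core of compound 1, amino to ethylamino leaves a step that stays within the scatter. Set side by side, the two steps cannot be told apart: the same change on two cores in this assay, a 1.7-fold lower number (0.24 log units; within the scatter) from compound 1 to compound 3 and a 1.2-fold higher number (0.08 log units; within the scatter) from compound 2 to compound 4, 2.1-fold (0.32 log units) apart, within the scatter of two such steps.

Within this series, the change can therefore be carried from one core to the other as a step of small size, though the evidence rests on only two pairs and does not show that the change has any effect of its own, nor that its direction is shared, as neither step can be distinguished from repeat-measurement scatter.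

On these data alone, on this nitrogen only hydrogen and ethyl appear, so it remains open whether a longer chain such as propyl or butyl, a cyclopropyl ring or an acetyl group would give a step beyond the scatter. As far as these compounds go, it also remains open whether the same small step would hold on a third core, or in any read-out other than this assay.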